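Shortening the Alkenyl Chain on the Piperidine Amine

The source may hold more compounds than are shown below. What is called first, only, known or untested is meant among the compounds shown, and "the series" means these compounds.

Measured so far:
Compound 1, `O=S(=O)(NCC1CCN(CCCc2c[nH]c3ccc(-n4cnnc4)cc23)CC1)c1ccccc1`, 6.2 nM
Compound 2, `c1ccc(CNC2CCN(CCCc3c[nH]c4ccc(-n5cnnc5)cc34)CC2)cc1`, 4.6 nM
Compound 3, `CC(C)=CCCN(C)C1CCN(CCCc2c[nH]c3ccc(-n4cnnc4)cc23)CC1`, 2.6 nM

All three compounds share one core and differ only in the group on the saturated ring carbon. In an assay on CHO cells for displacement of a labelled ligand from 5-hydroxytryptamine receptor 1D (Homo sapiens) (on this read-out lower numbers stand for stronger inhibition and higher numbers for weaker inhibition), compound 3 gives the lowest of the three numbers, yet its lead over compound 2 is small: the step of a 1.8-fold lower number from compound 2 to compound 3 (0.25 log units; within the scatter) lies within the scatter, so the two cannot be ranked against each other. Only against compound 1 does compound 3 stand apart, by the modest step of a 2.4-fold lower number from compound 1 to compound 3 (0.38 log units; beyond the scatter). The step of a 1.3-fold lower number from compound 1 to compound 2 (0.13 log units; within the scatter) is within the scatter as well.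

Compound 4, `CC(C)=CCN(C)C1CCN(CCCc2c[nH]c3ccc(-n4cnnc4)cc23)CC1`, keeps the methylamino attachment of compound 3 and changes only the alkenyl chain: 2-methylprop-1-en-1-yl in place of 3-methylbut-2-en-1-yl on a saturated chain carbon bound to an amine nitrogen. The same difference, cut one bond further out, reads methyl(4-methylpent-3-en-1-yl)amino to methyl(3-methylbut-2-en-1-yl)amino. Going by the values given here, no measured pair shows this exact change. The three measured steps, which swap far larger groups on the same ring carbon, all stay near the scatter, so a small change is expected here too. For compound 4 the estimated step of a 1.3-fold higher number from compound 3 to compound 4 (0.13 log units; within the scatter) is expected to be slight and somewhat toward a higher number. Compound 4 is therefore expected to give about 3.5 nM in this assay, within roughly 1.5 nM to 8 nM.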

Compound 4, half-maximal inhibitory concentration: 0.5 nM
Estimate against measurement, compound 4: 7.0-fold (0.85 log units) above; measured number below the stated range.
By their numbers in this assay, from the lowest: compound 4; then compounds 3, 2 and 1 (each within the scatter of the next, the first and the last beyond it).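

In this assay, this position proves sensitive to a small edit: going from 4-methylpent-3-en-1-yl to 3-methylbut-2-en-1-yl on the amine, which takes the chain from 5 carbon atoms to 4, gives a 5.2-fold lower number from compound 3 to compound 4 (0.72 log units; beyond the scatter). Going by these compounds alone, that step is larger than any among the earlier compounds, even though they swapped far bigger groups on the ring carbon and stayed near the scatter, so the overall size of the group is a poor guide to what happens here. The new compound also stands clear of the other two, with a 9.2-fold lower number from compound 2 to compound 4 (0.96 log units; beyond the scatter) and a 12-fold lower number from compound 1 to compound 4 (1.09 log units; beyond the scatter), which makes compound 4 the most potent of the four, while the earlier numbers gave no such clear leader; none of the data shown explains why this single shortening has so strong an effect.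

The compounds shown leave open whether the double bond itself matters, which a saturated 3-methylbutyl chain on the same amine would test. They also leave open whether shortening further helps or hurts, as a prop-2-en-1-yl group or a simple ethyl group would show.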